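Sulfonyl aryl swap from compound 2 to compound 3

This account rests on a few compounds, and the source may have more. Where it says the series, first, only, none or still open, it means among the compounds named here.

Compound 2 `N#C/N=C(\NCc1ccc(S(=O)(=O)c2ccccc2)cc1)Nc1ccncc1` carries a phenyl on the sulfonyl sulfur. In an ADME assay on microsomes from liver (Mus musculus) for metabolic stability, with a stated time of 30 min, tested at 1 uM (on this read-out higher numbers stand for a more stable compound and lower numbers for a less stable compound), compound 2 gives 57%. Compound 1 `COc1cccc(S(=O)(=O)c2ccc(CN/C(=N\C#N)Nc3ccncc3)cc2)c1` gives 58% in this assay, and the step of a number 1 percentage points lower from compound 1 to compound 2 (within the scatter) corresponds to hydrogen in place of methoxy on an aromatic carbon; the two values sit within the scatter of each other, so no order between them is drawn.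

Compound 3 `N#C/N=C(\NCc1ccc(S(=O)(=O)c2cccc3cccnc23)cc1)Nc1ccncc1` differs from compound 2 by quinolin-8-yl in place of phenyl on a sulfonyl sulfur. For the measured compounds named here, no measured step touches the aryl on the sulfonyl sulfur; the only measured step, a number 1 percentage points lower from compound 1 to compound 2 (within the scatter), is within the scatter and concerns another position, so it offers no direct guide. The expectation therefore starts from compound 2 at 57% with a widened range. Compound 3 is expected to give 50%, with a range of 25% to 75%. The step of a number 7 percentage points lower from compound 2 to compound 3 (within the scatter) is expected to be small, as nothing measured points to a change beyond the scatter.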

Compound 3, percent of the compound remaining: 11%
For compound 3 the middle estimate is 39 percentage points above the measured one, and the stated range ends above it.
By their numbers in this assay, from the lowest: compound 3; then compounds 2 and 1 (each within the scatter of the next).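

In this assay quinolin-8-yl in place of phenyl on a sulfonyl sulfur gives a number 46 percentage points lower from compound 2 to compound 3 (beyond the scatter) and quinolin-8-yl in place of 3-methoxyphenyl gives a number 47 percentage points lower from compound 1 to compound 3 (beyond the scatter) at the same place. The earlier pair showed only a number 1 percentage points lower from compound 1 to compound 2 (within the scatter) for methoxy and hydrogen on that aryl, so the read-out at this position is not insensitive once the aryl itself is replaced. Nothing available explains the size of this step.

The compounds shown leave open whether naphthalen-1-yl on the sulfonyl sulfur, which carries carbon where quinolin-8-yl carries its ring nitrogen, would read like quinolin-8-yl or like phenyl. Equally open, on these data alone, is where a single pyridin-3-yl ring at this place would fall.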